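The source may hold more compounds than are shown below. What is called first, only, known or untested is meant among the compounds shown, and "the series" means these compounds.

Measured compounds:
Compound 1 `COc1cc(/C=C/C(=O)/C=C/c2cccs2)ccc1OCc1cn(CCOc2cc(=O)oc3ccccc23)nn1` gives 66% in a functional assay on COLO 205 cells (Homo sapiens) for inhibition, read by sulforhodamine B assay, with a stated time of 48 h, tested at 50 uM; a lower number here means less inhibition of growth, a higher number more inhibition of growth at the concentration tested.
Compound 2 `COc1cc(/C=C/C(=O)/C=C/c2cc(OC)c(OC)c(OC)c2)ccc1OCc1cn(CCOc2cc(=O)oc3ccccc23)nn1` gives 86% in this assay.
Compound 3 `COc1cc(/C=C/C(=O)/C=C/c2cc(OC)c(OC)c(OC)c2)ccc1OCc1cn(CCCCOc2cc(=O)oc3ccccc23)nn1` gives 60% in this assay.

The three measured compounds share a chalcone-like chain with a triazole-linked coumarin portion. Compound 2 and compound 1 differ in one place: thiophen-2-yl in place of 3,4,5-trimethoxyphenyl on a double-bonded chain carbon bound to a double-bonded chain carbon. This change gave a number 20 percentage points lower from compound 2 to compound 1 (beyond the scatter). Compound 3 stands lowest of the three numbers; its value lies within the scatter of compound 1 and beyond the scatter of compound 2. The difference between the core of compound 3 and the core of compound 2 is not broken down here.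

Compound 4 `COc1cc(/C=C/C(=O)/C=C/c2cccs2)ccc1OCc1cn(CCCCOc2cc(=O)oc3ccccc23)nn1` has not been measured in this assay. It differs from compound 3 in the same way that compound 1 differs from compound 2: thiophen-2-yl in place of 3,4,5-trimethoxyphenyl on a double-bonded chain carbon bound to a double-bonded chain carbon, and the place is the same in both pairs. For the measured compounds named here, the step from compound 3 to compound 4 is therefore expected to resemble the step seen from compound 2 to compound 1, because a number 20 percentage points lower from compound 2 to compound 1 (beyond the scatter) shows what this change did once before, though only a single prior example is available. Compound 4 is expected to show a number 18 percentage points lower from compound 3 to compound 4 (beyond the scatter) in this assay. On this basis compound 4 is estimated at 42% in this assay, with a range from 25% to 58%.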

Compound 4, percent growth inhibition at one concentration: 40%
Compound 4: the middle estimate sits 2 percentage points above what was measured; low and high end bracket the measured number.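

In this assay, thiophen-2-yl in place of 3,4,5-trimethoxyphenyl on a double-bonded chain carbon bound to a double-bonded chain carbon gave a number 20 percentage points lower from compound 3 to compound 4 (beyond the scatter), and, set beside the earlier step, the change carried over from one core to the other with no difference in size: the same change on two cores in this assay, a number 20 percentage points lower (beyond the scatter) from compound 2 to compound 1 and a number 20 percentage points lower (beyond the scatter) from compound 3 to compound 4, 0 percentage points apart, within the scatter of two such steps Within these four compounds, then, the change can be treated as a step of its own, and its size did not depend on which of the two cores carried it, with no compound shown going against this. It does not show why the change lowers growth inhibition, and two pairs tested at one concentration, in one cell line, cannot establish that the step would hold on further cores or that it would appear in a full dose-response measurement.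

The compounds shown leave open how other groups would behave in that same place, such as a plain phenyl, a furan-2-yl or a phenyl ring bearing an amine, and whether they would fall on the thiophen-2-yl side or the 3,4,5-trimethoxyphenyl side of this step. They also leave open whether the step would keep its size on a core with a longer chain leading to the triazole.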